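Difluoromethoxy Replaces Butyl on an Aryl Sulfonamide

A few compounds are considered here, and "the series" means these few. Any claim that something is new, unique, unknown or untested is made for them only; others in the source may bear on it.

Of the compounds shown here, two sharing the same core have been measured in a functional assay on MCF7 cells (Homo sapiens) for antiproliferative activity, read by sulforhodamine B assay, with a stated time of 48 h; a lower number here means a stronger inhibitor, a higher number a weaker inhibitor. Compound 1 `O=C1NCCN1c1ccc(S(=O)(=O)Nc2ccc3[nH]ccc3c2)cc1` carries an indole on the sulfonamide nitrogen, and in this assay compound 1 gives 170 nM. Compound 2 `CCCCc1ccc(NS(=O)(=O)c2ccc(N3CCNC3=O)cc2)cc1` carries a butylphenyl group instead, and in this assay compound 2 gives 770 nM, the highest of the two numbers and beyond the scatter from compound 1. Compound 3 `O=C1NCCN1c1ccc(S(=O)(=O)Nc2ccc(OC(F)F)cc2)cc1` is the compound not yet measured. It differs from compound 2 at one place: difluoromethoxy in place of butyl on an aromatic carbon.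

Among the measured compounds shown here, no step between two measured compounds is available for this kind of change, so the expectation for compound 3 rests on compound 2 alone. The step from compound 2 to compound 3 is expected to be small, a 1.3-fold lower number from compound 2 to compound 3 (0.11 log units; within the scatter), not clearly beyond the scatter in either direction. In this assay compound 3 is therefore estimated at 600 nM, with a range from 200 nM to 2000 nM.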

Compound 3, half-maximal inhibitory concentration: 760 nM
Estimate against measurement, compound 3: 1.3-fold (0.10 log units) below, within the range that was stated.
By their numbers in this assay, from the lowest: compound 1; then compounds 3 and 2 (each within the scatter of the next).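

In this assay, difluoromethoxy in place of butyl on an aromatic carbon, para to a large group, gives a 1.0-fold lower number from compound 2 to compound 3 (0.01 log units; within the scatter) and so separates the two groups by nothing that can be read. The entering group brings oxygen, fluorine and a hydrogen-bond acceptor where butyl has carbon only, and on this aryl sulfonamide that exchange leaves the number in this assay within the scatter. No measurement at hand speaks to why the two groups read alike.

Whether an amine, a carboxylic acid or a longer chain at this same place would also read alike remains open, with butyl and difluoromethoxy the only two groups shown there. No single-place step yet links either of these compounds to the indole of compound 1.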